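The source may hold more compounds than are shown below. What is called first, only, known or untested is meant among the compounds shown, and "the series" means these compounds.

Measured so far in a functional assay on DU-145 cells (Homo sapiens) for inhibition, read by CCK-8 assay, with a stated time of 72 h; a lower number here means a stronger inhibitor, a higher number a weaker inhibitor:
- compound 1 `O=C(/C=C/c1cccnc1)NCCCCc1ccc(S(=O)(=O)Nc2ccccc2)cc1`: 47.9 nM
- compound 2 `Cc1cccc(NS(=O)(=O)c2cccc(CCCCCCNC(=O)/C=C/c3cccnc3)c2)c1`: 41.7 nM

Compound 2 and compound 1 lie within the scatter of each other, so neither leads the series. Compound 3 `CC(C)(C)c1ccc(NS(=O)(=O)c2cccc(CCCCCCNC(=O)/C=C/c3cccnc3)c2)cc1` is next, with this change from compound 2: 4-(tert-butyl)phenyl in place of 3-methylphenyl on a sulfonamide nitrogen. This puts 4-(tert-butyl)phenyl in place of 3-methylphenyl on a sulfonamide nitrogen. Among the compounds with values here, no measured step yet shows the effect of such a swap, so the expectation is loose. The expected move, a 1.7-fold higher number from compound 2 to compound 3 (0.22 log units; within the scatter), is small, toward a higher number, and not clearly beyond the scatter. The estimate for compound 3 is 70 nM, with an expected range of 25 nM to 200 nM.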

Compound 3, half-maximal inhibitory concentration: 281 nM
Estimate against measurement, compound 3: 4.0-fold (0.60 log units) below; measured number outside the range, above it.
By their numbers in this assay, from the lowest: compounds 2 and 1 (each within the scatter of the next); then compound 3.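

The aryl group on the sulfonamide nitrogen matters in this assay: 4-(tert-butyl)phenyl in place of 3-methylphenyl gives a weaker inhibitor (a 6.7-fold higher number from compound 2 to compound 3 (0.83 log units; beyond the scatter)). Within the data shown here, this is the first step that lies beyond the scatter, so this position does not accept both aryl groups equally. Nothing measured here accounts for the step.

The swap changes both the group and its place on the ring, so the two remain unseparated. A 4-methylphenyl or 3-(tert-butyl)phenyl group on the same nitrogen would tell them apart.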